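From 2-chlorobenzyl to 2,4-dichlorobenzyl: a small step expected

The source may hold more compounds than are shown below. What is called first, only, known or untested is meant among the compounds shown, and "the series" means these compounds.

Compound 1 `O=[N+]([O-])c1cc(C(F)(F)F)cc([N+](=O)[O-])c1Oc1ccc(Cl)cc1/C=N\OCc1ccccc1`, compound 2 `O=[N+]([O-])c1cc(C(F)(F)F)cc([N+](=O)[O-])c1Oc1ccc(Cl)cc1/C=N\OCc1ccccc1F` and compound 3 `O=[N+]([O-])c1cc(C(F)(F)F)cc([N+](=O)[O-])c1Oc1ccc(Cl)cc1/C=N\OCc1ccccc1Cl` share one core and differ only in a single substituent on one aromatic ring. In a functional assay on HepG2 cells (Homo sapiens) for antiproliferative activity, read by MTT assay, with a stated time of 48 h (on this read-out lower numbers stand for stronger inhibition and higher numbers for weaker inhibition), compound 1 gives 1790 nM, compound 2 gives 1020 nM and compound 3 gives 1510 nM. These numbers all lie within the usual scatter of one another, so compound 3 cannot be ranked against the other two.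

Compound 4 `O=[N+]([O-])c1cc(C(F)(F)F)cc([N+](=O)[O-])c1Oc1ccc(Cl)cc1/C=N\OCc1ccc(Cl)cc1Cl` turns the 2-chlorobenzyl group of compound 3 into 2,4-dichlorobenzyl, with chloro in place of hydrogen on an aromatic carbon. The closest guide is the earlier chloro step, a 1.2-fold lower number from compound 1 to compound 3 (0.07 log units; within the scatter). The fluoro step, a 1.8-fold lower number from compound 1 to compound 2 (0.24 log units; within the scatter), and the swap of fluoro for chloro, a 1.5-fold higher number from compound 2 to compound 3 (0.17 log units; within the scatter), also stayed within the scatter. None of these compounds carries a group para to a large group, so the guide is imperfect.

In this assay the expected step is small, a 1.2-fold lower number from compound 3 to compound 4 (0.07 log units; within the scatter), and no shift beyond the scatter is expected. The estimated value for compound 4 is 1300 nM, with an expected range from 600 nM to 2800 nM.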

Compound 4, half-maximal inhibitory concentration: 1280 nM
Estimate against measurement, compound 4: 1.0-fold (0.01 log units) above, within the range that was stated.
By their numbers in this assay, from the lowest: compounds 2, 4, 3 and 1 (each within the scatter of the next).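

In this assay, adding a second chloro group to the benzyl ring, para to a large group and meta to the existing chloro group, gives a step that cannot be told from the scatter (a 1.2-fold lower number from compound 3 to compound 4 (0.07 log units; within the scatter)). The two wider comparisons also stay within the scatter (a 1.3-fold higher number from compound 2 to compound 4 (0.10 log units; within the scatter); a 1.4-fold lower number from compound 1 to compound 4 (0.15 log units; within the scatter)), so even two chloro groups on this ring leave compound 4 not clearly separated from compound 1, with its plain benzyl group. Nothing measured here bears on why the read-out stays so flat.

The ring substituents shown are only fluoro and chloro, so it remains open whether a methoxy group, an amine or a carboxylic acid at the same position would move the number beyond the scatter. From the compounds shown here alone, it also remains open whether the same holds with a longer chain joining the oxygen to this ring.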